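The source may hold more compounds than are shown below. What is called first, only, known or untested is meant among the compounds shown, and "the series" means these compounds.

Compound 1 `O=c1[nH]c(=O)n(CCC(CO)CO)cc1-c1ccco1` gives in a functional assay on HeLa cells (Homo sapiens) for antiproliferative activity, read by MTT assay, with a stated time of 72 h (a higher number here means a weaker inhibitor, a lower number a stronger inhibitor), only a limit, > 100000 nM. Compound 2 `CC(=O)OCC(CCn1cc(C#Cc2cc(F)cc(F)c2)c(=O)n(C(=O)c2ccccc2)c1=O)COC(C)=O` gives 64500 nM. Compound 3 `CC(=O)OCC(CCn1cc(C#CCc2ccccc2)c(=O)n(C(=O)c2ccccc2)c1=O)COC(C)=O` gives 29900 nM.

Compound 1 thus stands at the edge of what this assay reports: its value is a limit and not a number, which is where one of the three results shown sits (the limit of > 100000 nM in this assay, at which 1 of the 3 values shown sits). For the measured compounds named here, the two numbers that are known, from compound 2 and compound 3, both fall in the weak range, and the only measured step is a 2.2-fold lower number from compound 2 to compound 3 (0.33 log units; beyond the scatter).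

The step to be followed leads from compound 1 to compound 4 `CCCCCC#Cc1cn(CCC(CO)CO)c(=O)[nH]c1=O`, with hept-1-yn-1-yl in place of furan-2-yl on an aromatic carbon. Going by the values given here, no measured step concerns this exchange on the shared core of compound 1; the one known step, from compound 2 to compound 3, changes what sits on a triple-bonded carbon and was modest, so it offers only a loose parallel. With compound 1 at a limit, the direction of any step cannot be read from the data; what the alkyne-bearing compounds 2 and 3 show is weak activity that is at least measurable.

The expectation for compound 4 is therefore a weak but possibly measurable value, 80000 nM with a range of 20000 nM to 300000 nM, and a step of an at least 1.2-fold lower number from compound 1 to compound 4 (0.09 log units; that floor lies within the scatter) that is estimated, not measured, with a fair chance that only a limit is reported.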

Compound 4, half-maximal inhibitory concentration: 76300 nM
Estimate against measurement, compound 4: 1.0-fold (0.02 log units) above; the measured number falls inside the stated range.
By their numbers in this assay, from the lowest: compound 3; then compounds 2 and 4 (each within the scatter of the next). At a limit, above all of these: compound 1.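

Compound 1 gives > 100000 nM in this assay, which is a limit of the assay and not a number. Exchanging furan-2-yl for hept-1-yn-1-yl on this aromatic carbon brings the shared core to a measured value, a ringless chain in place of the five-membered aromatic ring, and the change reads as an at least 1.3-fold lower number from compound 1 to compound 4 (0.11 log units; that floor lies within the scatter). Since only a floor is known for this step, and that floor lies within the scatter, the result gives a number for compound 4 but no firm size for the change, because one end of the comparison is a limit: the limit of > 100000 nM in this assay, at which 1 of the 4 values shown sits.

As far as these compounds go, what stays open is how the value on this core would respond to a shorter or longer chain on the triple bond, or to an amine or a carboxylic acid at the end of that chain. Also open is whether the benzoyl and acetyl groups carried by compound 2 and compound 3 matter on this core, as no pair shown isolates them.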